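Working notes: fluoro to trifluoromethyl on compound 2

A few compounds are considered here, and "the series" means these few. Any claim that something is new, unique, unknown or untested is made for them only; others in the source may bear on it.

Compound 1 `COc1ccc(/C=C/C(=O)c2ccc(OC)c3c2OC(C)(C)C=C3)c(F)c1` gives 7560 nM in a functional assay on HepG2 cells (Homo sapiens) for antiproliferative activity, read by MTT assay, with a stated time of 24 h; on this read-out lower numbers stand for stronger inhibition and higher numbers for weaker inhibition. Compound 2 `COc1ccc(C(=O)/C=C/c2cccc(F)c2)c2c1C=CC(C)(C)O2` reports only a limit in this assay, > 10000 nM. Compound 3 `COc1ccc(/C=C/C(=O)c2ccc(OC)c3c2OC(C)(C)C=C3)cn1` likewise reports only a limit, > 10000 nM. Both of these values sit at the limit of > 10000 nM in this assay, at which 2 of the 3 values shown sit, so compound 2 stands at the limit and not at a number, and its position relative to compound 3 cannot be read. The measured steps are an at least 1.3-fold higher number from compound 1 to compound 2 (0.12 log units; that floor lies within the scatter) and an at least 1.3-fold higher number from compound 1 to compound 3 (0.12 log units; that floor lies within the scatter), each with a floor inside the scatter, while a step that the two limits leave unreadable from compound 2 to compound 3 gives no readable size.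

Compound 4 `COc1ccc(C(=O)/C=C/c2cccc(C(F)(F)F)c2)c2c1C=CC(C)(C)O2` differs from compound 2 by trifluoromethyl in place of fluoro on an aromatic carbon. Going by the values given here, none of the measured steps changes this single substituent; each of them swaps the whole aryl group, so none bears directly on the size or direction of this step. Among the compounds with values here, with compound 2 at the limit, the change is expected to give no step readable beyond the scatter, and the most likely outcome is again a limit in this assay. The step that the limit leaves unreadable from compound 2 to compound 4 is therefore estimated to stay within the scatter. Compound 4 is expected at 12000 nM, with a range from 5000 nM to 30000 nM.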

Compound 4, half-maximal inhibitory concentration: > 10000 nM
Compound 4 ended at the assay's limit (the forecaster's own chance of this, stated with the estimate: 65%); the middle value is on the limit's open side.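

Compound 2 and compound 4 both stand at a limit in this assay and not at a number, so no step can be read for trifluoromethyl in place of fluoro: the limit of > 10000 nM in this assay, at which 3 of the 4 values shown sit.

The compounds shown leave open how far compound 2 and compound 4 actually lie from each other, and in which direction, in this assay.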